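The compounds below may be only part of what the source reports. "The series", "measured", "known", "first", "only" and "open" are said of these compounds alone.

Values in a functional assay on MDA-MB-231 cells (Homo sapiens), read by wound healing assay, with a stated time of 24 h (on this read-out higher numbers stand for weaker inhibition and lower numbers for stronger inhibition), are as follows:

- compound 1 `CC(=O)O[C@H]1CC[C@]2(C)[C@H](CC[C@@](C)(O)[C@H]2CC[C@@H]2C(C)=CC[C@H]3[C@H](CC[C@]3(C)O)C2(C)C)OC1(C)C` gives 16800 nM
- compound 2 `CC1=CC[C@H]2[C@H](CC[C@]2(C)O)C(C)(C)[C@@H]1CC[C@H]1[C@]2(C)CC[C@H](OC(=O)c3ccncc3)C(C)(C)O[C@H]2CC[C@@]1(C)O` gives 10600 nM; 10600 nM (2 entries)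
- compound 3 `CC1=CC[C@H]2[C@H](CC[C@]2(C)O)C(C)(C)[C@@H]1CC[C@H]1[C@]2(C)CC[C@H](OC(=O)c3ccc([N+](=O)[O-])cc3)C(C)(C)O[C@H]2CC[C@@]1(C)O` gives 3350 nM; 3400 nM (2 entries)

Compound 1 is the only one of the three with a single reading. Compound 2 and compound 3 each have two entries, and those of compound 3 agree closely (the several entries of compound 3 in this assay, 3350 nM; 3400 nM (2 entries)). The value of compound 1 lies close to that of compound 2 and well above that of compound 3.

Compound 4 `CC1=CC[C@H]2[C@H](CC[C@]2(C)O)C(C)(C)[C@@H]1CC[C@H]1[C@]2(C)CC[C@H](OC(=O)c3ccccc3Cl)C(C)(C)O[C@H]2CC[C@@]1(C)O` keeps the shared core and has 2-chlorophenyl in place of methyl on a carbonyl carbon. Among the compounds with values here, no measured step isolates this change. Compound 2 and compound 3 also carry an aromatic ring on that carbonyl carbon, but they do not behave alike: compound 3 at 3350 nM; 3400 nM (2 entries) sits well under compound 1 at 16800 nM and compound 2 at 10600 nM; 10600 nM (2 entries) stays near it. A modest move toward stronger inhibition in this assay is therefore expected, perhaps not far beyond the scatter. The expected change is a 2.4-fold lower number from compound 1 to compound 4 (0.38 log units; beyond the scatter) on this estimate. For compound 4 the estimated value is 7000 nM with an expected range from 2800 nM to 16000 nM in this read-out.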

Compound 4, half-maximal inhibitory concentration: 14100 nM
Beside the measured number, compound 4's estimate is 2.0-fold (0.30 log units) below it; measured number inside the range.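

In this assay, 2-chlorophenyl in place of methyl on a carbonyl carbon brings a 1.2-fold lower number from compound 1 to compound 4 (0.08 log units; within the scatter), so this much larger group, with its six-membered aromatic ring, leaves the read-out where it was. An aromatic ring on that carbonyl carbon is therefore not enough in itself to give a low number, since compound 4 at 14100 nM stands well above compound 3 at 3350 nM; 3400 nM (2 entries). The low reading of compound 3 does not rest on one stray entry: the several entries of compound 3 in this assay, 3350 nM; 3400 nM (2 entries)

The compounds shown leave open whether a plain phenyl or an aminophenyl on that carbonyl carbon would read nearer to compound 3 or to compound 4. Also open, on these data alone, is how a longer alkyl chain in place of methyl there would read.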